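A few compounds are considered here, and "the series" means these few. Any claim that something is new, unique, unknown or untested is made for them only; others in the source may bear on it.

In an ADME assay on CHO cells (Cricetulus griseus) for cytotoxicity, read by LDH release (on this read-out higher numbers stand for weaker inhibition and lower numbers for stronger inhibition), compound 2 `Cc1ccc(CNC(=O)C(C)Oc2ccc(Cl)cc2Cl)cc1` gives 25000 nM. Of the two numbers recorded in this assay, that of compound 2 is the larger, yet the gap to compound 1 `CC(Oc1ccc(Cl)cc1Cl)C(=O)NCc1cccc(Cl)c1`, which gives 19000 nM, stays within the scatter of the method, so the two compounds cannot be told apart. Compound 3 `CC(Oc1ccc(Cl)cc1Cl)C(=O)NCc1ccc(F)nc1` has not yet been measured. It differs from compound 2 in one place: 6-fluoropyridin-3-yl in place of 4-methylphenyl on a saturated chain carbon bound to an amide-type nitrogen. For the measured compounds named here, the single measured step that bears on this place is a 1.3-fold higher number from compound 1 to compound 2 (0.12 log units; within the scatter), where one aromatic ring gave way to another on the same saturated chain carbon and the number barely moved. On that evidence a further swap of ring at the same place is expected to leave the number in this assay roughly where it stands, so for compound 3 a step of a 1.0-fold lower number from compound 2 to compound 3 (0.02 log units; within the scatter) is expected, amounting to no change beyond the scatter. Compound 3 is therefore estimated at 24000 nM, with a likely range from 11000 nM to 50000 nM.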

Compound 3, half-maximal inhibitory concentration: > 100000 nM
Compound 3: only a limit was reported (the forecaster's own chance of this, stated with the estimate: 15%); at least 4.1-fold (0.61 log units) between middle value and limit.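

The earlier pair, with its two carbon-only aromatic rings, gave no sign that this place on the saturated chain carbon bound to an amide-type nitrogen matters in this assay. The 6-fluoropyridin-3-yl group shows that it does, with an at least 4.0-fold higher number from compound 2 to compound 3 (0.60 log units; beyond the scatter) and with an at least 5.2-fold higher number from compound 1 to compound 3 (0.72 log units; beyond the scatter); a higher number here means weaker inhibition, so this ring change moves the compound away from cell toxicity in this read-out. Compound 3 carries only a limit of the assay, not a number, so both steps are minimum sizes: the limit of > 100000 nM in this assay, at which 1 of the 3 values shown sits.

Open, on these data alone, is whether the ring nitrogen, the fluorine or the two together go with this change, since the entering group brings both at once. A fluorophenyl ring, or a pyridine ring without fluorine, at this place would separate the two.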